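The source may hold more compounds than are shown below. What is called first, only, known or untested is meant among the compounds shown, and "the series" means these compounds.

Going by the values given here, in an ADME assay on microsomes from liver (Rattus norvegicus) for metabolic stability (a higher number here means faster removal of the compound, a lower number slower removal), compound 3 `CC(C)(C)C(Oc1ccc(-n2cc(C(F)(F)F)cn2)cc1)c1ccc(C(=O)NCCC(=O)O)cc1` gives 28 mL/min/kg, the only actual number in this small series. Compound 1 `O=C(O)CCNC(=O)c1ccc(C(Oc2ccc(-n3cc(C(F)(F)F)cn3)cc2)C2CC2)cc1` is reported as < 25 mL/min/kg, which is a limit of the assay and not a number. Compound 2 `CCC(Oc1ccc(-n2cc(C(F)(F)F)cn2)cc1)c1ccc(C(=O)NCCC(=O)O)cc1` is likewise reported only as a limit, < 25 mL/min/kg. Compound 4 `CCCC(Oc1ccc(-n2cc(C(F)(F)F)cn2)cc1)c1ccc(C(=O)NCCC(=O)O)cc1` has propyl in place of tert-butyl on a saturated chain carbon bound to an aromatic carbon and an oxygen on an aromatic ring. The closest measured change is an at least 1.1-fold higher number from compound 2 to compound 3 (0.04 log units; that floor lies within the scatter), and an at least 1.1-fold higher number from compound 1 to compound 3 (0.04 log units; that floor lies within the scatter) also bears on it. Both are floors within the scatter, and both rest on (the limit of < 25 mL/min/kg in this assay, at which 2 of the 3 values shown sit). The expected step is a 1.3-fold lower number from compound 3 to compound 4 (0.10 log units; within the scatter), which would not go beyond the scatter. For compound 4 the estimated value is 22 mL/min/kg, with an expected range of 12 mL/min/kg to 38 mL/min/kg.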

Compound 4, clearance: < 36 mL/min/kg
Compound 4: a limit, no number (the forecaster's own chance of this, stated with the estimate: 55%); the middle value lies beyond the limit too.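

In this assay, going by these compounds alone, compound 4 gives < 36 mL/min/kg as a limit and not a number, so no step between it and compound 1, compound 2 or compound 3 can be read. The compounds shown leave open whether propyl in place of tert-butyl changes clearance at all.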